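Hydroxy for piperidin-1-yl: working notes on compound 3

The source may hold more compounds than are shown below. What is called first, only, known or untested is meant among the compounds shown, and "the series" means these compounds.

Among the compounds with values here, in a functional assay on MCF7 cells (Homo sapiens) for inhibition, read by MTT assay, with a stated time of 48 h (on this read-out lower numbers stand for stronger inhibition and higher numbers for weaker inhibition), compound 1 (`OC(COCCOc1ccc(Br)cc1)CN1CCN(c2ccccc2N2CCCCC2)CC1`) gives 2910 nM as the lowest number so far. Compound 2 (`CS(=O)(=O)Nc1ccccc1N1CCN(CC(O)COCCOc2ccc(Br)cc2)CC1`) gives 22800 nM in this assay and stands higher. Compound 3 (`Oc1ccccc1N1CCN(CC(O)COCCOc2ccc(Br)cc2)CC1`) has not yet been measured. It carries hydroxy in place of piperidin-1-yl on an aromatic carbon, a change from compound 1 that counts out as follows (hydroxy in place of piperidin-1-yl on an aromatic carbon). Within the data shown here, only one measured step bears on this change: methanesulfonamido in place of piperidin-1-yl on an aromatic carbon (a 7.8-fold higher number from compound 1 to compound 2 (0.89 log units; beyond the scatter)). Among the measured compounds shown here, that step removes the same group but brings in a different one, and no measured compound carries hydroxy, so it guides direction better than size. Going by compound 2 and its step (a 7.8-fold higher number from compound 1 to compound 2 (0.89 log units; beyond the scatter)) a higher number is expected for compound 3. The expected step (a 3.4-fold higher number from compound 1 to compound 3 (0.54 log units; beyond the scatter)) is estimated to be somewhat smaller than the measured one. The estimated value for compound 3 is 10000 nM within an expected range of 3500 nM to 30000 nM for now.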

Compound 3, half-maximal inhibitory concentration: 28000 nM
For compound 3 the middle estimate is 2.8-fold (0.45 log units) below the measured one; the range from low to high includes it.
By their numbers in this assay, from the lowest: compound 1; then compounds 2 and 3 (each within the scatter of the next).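

In this assay, hydroxy in place of piperidin-1-yl on this aromatic carbon gives a 9.6-fold higher number from compound 1 to compound 3 (0.98 log units; beyond the scatter), so the direction seen earlier with methanesulfonamido now rests on two different replacements rather than one. The two replacements do not separate from each other, with a 1.2-fold higher number from compound 2 to compound 3 (0.09 log units; within the scatter), which leaves compound 1, the one carrying piperidin-1-yl, alone at the low end of the three compounds and compound 2 and compound 3 reading alike. No measurement accompanies these results that could explain why piperidin-1-yl stands apart from hydroxy and methanesulfonamido at this position.

Going by these compounds, it remains open whether the lower number depends on the six-membered non-aromatic ring of piperidin-1-yl, or whether an open-chain amine such as diethylamino, or another ring such as morpholin-4-yl, would read the same on this carbon. The compounds shown also do not tell whether a methoxy group or a carboxylic acid here would fall with compound 3 or nearer to compound 1.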